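Bulkier Ketone Side Chain in a Lipoxygenase Inhibitor Pair

The compounds below may be only part of what the source reports. "The series", "measured", "known", "first", "only" and "open" are said of these compounds alone.

Compound 2 `CC(=O)c1cccc(N2CCCC(=O)N2)c1` stands at the weaker end of the two values known in an assay on isolated protein for inhibition of Polyunsaturated fatty acid 5-lipoxygenase (Homo sapiens); a lower number here means a stronger inhibitor, a higher number a weaker inhibitor: compound 2 gives 19000 nM, the highest of the two numbers. Among the compounds with values here, its only neighbour is compound 1 `Cc1cccc(N2CCCC(=O)N2)c1`, which in this assay gives 3400 nM; the step of a 5.6-fold higher number from compound 1 to compound 2 (0.75 log units; beyond the scatter) placed acetyl in place of methyl on an aromatic carbon, and that step lies beyond the scatter.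

Compound 3 `CC(C)(C)C(=O)c1cccc(N2CCCC(=O)N2)c1` has not been measured. It differs from compound 2 by tert-butyl in place of methyl on a carbonyl carbon. Within the data shown here, no measured step exchanges one alkyl group for a larger one on the carbonyl carbon, so the only comparison available is the acetyl-for-methyl step from compound 1 to compound 2, which concerns a different change. Among the measured compounds shown here, the record therefore gives no direction for this step, and no movement beyond the scatter is expected for compound 3, which is estimated at 20000 nM in this assay with a range from 6000 nM to 70000 nM. The expected step of a 1.1-fold higher number from compound 2 to compound 3 (0.02 log units; within the scatter) is thus small.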

Compound 3, half-maximal inhibitory concentration: 15000 nM
Compound 3: middle estimate off by 1.3-fold (0.12 log units), on the high side; the measured number falls inside the stated range.
By their numbers in this assay, from the lowest: compound 1; then compounds 3 and 2 (each within the scatter of the next).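

In this assay the step of a 1.3-fold lower number from compound 2 to compound 3 (0.10 log units; within the scatter) stays within the scatter, so on this carbonyl carbon, tert-butyl and methyl cannot be told apart, even though four carbons enter where one leaves. The earlier pair showed only that acetyl and methyl on the aromatic carbon differ; the step of a 4.4-fold higher number from compound 1 to compound 3 (0.64 log units; beyond the scatter) now shows that (tert-butyl)carbonyl also lies beyond the scatter from methyl, on the same side as acetyl, so both ketones give higher numbers than compound 1. No measurement at hand bears on why the two ketones stand so close.

On these data alone, whether this indifference extends beyond these two alkyl groups remains open, for instance to a phenyl ring on the carbonyl carbon or to an amine there, which would turn the ketone into an amide. Also open, as far as these compounds go, is whether an alcohol in place of the carbonyl, or a longer alkyl chain in place of methyl on the aromatic carbon, would stay close to compound 1 or move towards the two ketones.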